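Removing One Chloro Group from a Urea ACAT Inhibitor

This account rests on a few compounds, and the source may have more. Where it says the series, first, only, none or still open, it means among the compounds named here.

Two ureas have been measured here. Compound 2 `Cc1cc(Cl)c(NC(=O)N(Cc2ccc(Oc3ccc(F)cc3)cc2)C2CCCCCC2)c(Cl)n1` carries two chloro groups on its pyridine-like ring next to the urea, and in an assay for inhibition of acyl-CoA:cholesterol acyltransferase (Oryctolagus cuniculus), using microsomes (a lower number here means a stronger inhibitor, a higher number a weaker inhibitor), compound 2 gives 14 nM. Compound 1 `CSc1cc(C)nc(SC)c1NC(=O)N(Cc1cccc(Oc2ccc(Br)cc2)c1)C1CCCCCC1` differs in several places at once, and in this assay compound 1 gives 73 nM. Of the two numbers, compound 2 has the lower one; the number for compound 1 is higher by a gap that lies beyond the usual scatter, so compound 2 is the stronger inhibitor of this pair.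

Compound 3 `Cc1ccc(NC(=O)N(Cc2ccc(Oc3ccc(F)cc3)cc2)C2CCCCCC2)c(Cl)n1` has not been measured. It differs from compound 2 in one place: hydrogen in place of chloro on an aromatic carbon. Compounds 1 and 2 differ in more than one place. Among the compounds with values here, no single-change step between measured compounds tells how much a chloro group on that ring contributes. The loss of one small group from a well-tolerated position is expected to shift the number only moderately upward, toward weaker inhibition, with the step of a 2.9-fold higher number from compound 2 to compound 3 (0.46 log units; beyond the scatter) expected to be small. Compound 3 is therefore estimated at 40 nM in this assay, with a likely range from 12 nM to 130 nM.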

Compound 3, half-maximal inhibitory concentration: 19 nM
Compound 3: middle estimate off by 2.1-fold (0.32 log units), on the high side, and the stated range covers the measured number.
By their numbers in this assay, from the lowest: compounds 2 and 3 (each within the scatter of the next); then compound 1.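

In this assay, putting hydrogen in place of chloro on this aromatic carbon, opposite the ring nitrogen, gives a 1.4-fold higher number from compound 2 to compound 3 (0.13 log units; within the scatter) and so stays within the scatter. Within the data shown here, this is the first step here that isolates a single change, and it shows that this chloro group can be lost without a difference that the assay can distinguish from the scatter of repeated measurements. Compounds 1 and 2 differ in more than one place and could not show this, and nothing measured here gives a reason for the result.

As far as these compounds go, the result covers only hydrogen and chloro at this one position, so it remains open whether a larger or different group there, such as an amine, a methoxy group or a nitrile, would give a similar number. The other chloro group on the ring of compound 3 also remains unresolved, as no single-change step among these compounds shows what that group contributes.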